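This account rests on a few compounds, and the source may have more. Where it says the series, first, only, none or still open, it means among the compounds named here.

Measured so far in an ADME assay on HEL cells (Homo sapiens) for cytotoxicity, with a stated time of 3 days; on this read-out higher numbers stand for lower toxicity in this test and lower numbers for higher toxicity in this test:
- compound 1, `CCCCCc1ccc(CCc2cc3cn([C@H]4C[C@H](O)[C@@H](CO)O4)c(=O)nc3o2)cc1`, >= 470000 nM
- compound 2, `CCCCCCc1ccc(-c2cc3cn([C@H]4C[C@H](O)[C@@H](CO)O4)c(=O)nc3o2)cn1`, 100000 nM

Compound 1 is known in this assay only as a limit, (the limit of >= 470000 nM in this assay, at which 1 of the 2 values shown sits), and not as a number, so it cannot be placed against compound 2 with any precision. Compound 2, which carries the hexyl tail on a different aromatic ring joined directly to the shared core, gives 100000 nM in this assay. Taken together, the two entries show that compound 2 sits at a measured value where compound 1 only reaches a limit; more than that cannot be read from them.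

Compound 3, `O=c1nc2oc(CCc3ccccc3)cc2cn1[C@H]1C[C@H](O)[C@@H](CO)O1`, differs from compound 1 in one place: hydrogen in place of pentyl on an aromatic carbon. Among the measured compounds shown here, no step between measured compounds tracks this change, so the direction is not anchored. Since compound 1 already lies at the limit, the step from compound 1 to compound 3 in this assay is expected to be none beyond the scatter, with the outcome most likely again reported as a limit, a number no higher from compound 1 to compound 3 (the limit leaves the size open). Compound 3 is therefore expected to give about 470000 nM in this assay, within 200000 nM to 1000000 nM.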

Compound 3, minimum cytotoxic concentration: > 560000 nM
Compound 3 gave a limit, no number (the forecaster's own chance of this, stated with the estimate: 70%); middle value at least 1.1-fold (0.07 log units) away from the limit.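

In this assay compound 1 gives >= 470000 nM as a limit only. Compound 3 likewise gives > 560000 nM as a limit only, so no new step can be read between compound 1 and compound 3. As far as these compounds go, whether hydrogen in place of pentyl on an aromatic carbon changes the read-out at all, and in which direction, stays open.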